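This account rests on a few compounds, and the source may have more. Where it says the series, first, only, none or still open, it means among the compounds named here.

Compound 1 `CC(C(=O)NCc1ccc(C(C)(C)C)nc1SCCCN1CCCC1)c1ccc(NS(C)(=O)=O)c(F)c1` and compound 2 `CC(C(=O)NCc1ccc(C(C)(C)C)cc1N1CCCC1)c1ccc(NS(C)(=O)=O)c(F)c1` share one core and were both tested in an assay on cells for antagonist activity at transient receptor potential cation channel subfamily V member 1 (Homo sapiens), read by FLIPR and calcium flux, with a stated time of 6 min; a higher number here means a weaker inhibitor, a lower number a stronger inhibitor. Compound 1 gives 17.1 nM, while compound 2 gives 8.1 nM, the lowest of the two numbers; the gap between them lies beyond the usual scatter. Compound 3 `CC(C(=O)NCc1ccc(C(C)(C)C)cc1N1CCN(c2ccccc2)CC1)c1ccc(NS(C)(=O)=O)c(F)c1` has not yet been measured. It differs from compound 2 in one place: 4-phenylpiperazin-1-yl in place of pyrrolidin-1-yl on an aromatic carbon. Within the data shown here, no measured pair shows a change of this kind, so the size of the step is uncertain; a modest weakening is expected, a 2.5-fold higher number from compound 2 to compound 3 (0.39 log units; beyond the scatter). Compound 3 is estimated at 20 nM, within 5 nM to 90 nM.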

Compound 3, inhibition constant: 0.8 nM
The estimate for compound 3 lay 25-fold (1.40 log units) above the measured number, outside the stated range (below it).
By their numbers in this assay, from the lowest: compound 3; then compound 2; then compound 1.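

This position, on an aromatic carbon ortho to a large group and meta to a tert-butyl group, accepts a far larger substituent than pyrrolidin-1-yl. In this assay, 4-phenylpiperazin-1-yl gives a 10-fold lower number from compound 2 to compound 3 (1.01 log units; beyond the scatter) and so a stronger inhibitor, a large step beyond the scatter. Nothing measured here explains the change.

The compounds shown leave open whether the piperazine ring, the phenyl ring or both matter. A 4-methylpiperazin-1-yl group or a piperidin-1-yl group at this place would help separate those parts.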